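Swapping a Methoxy for Chloro on the Sulfonyl Ring

The source may report more compounds than this note shows. Statements on the series, on what has been measured and on what is new or still open speak of the compounds shown alone.

Compound 2 `COc1ccc(OC)c(S(=O)(=O)n2cc(/C=N/N=C/N(C)C)c3c([N+](=O)[O-])cccc32)c1` is one of two compounds tested in a functional assay on HEK293 cells for inhibition of 5-hydroxytryptamine receptor 6 (Homo sapiens), read by calcium flux and cAMP accumulation, with a stated time of 10 min (on this read-out higher numbers stand for weaker inhibition and lower numbers for stronger inhibition), where compound 2 gives 1400 nM. Its companion, compound 1 `CN(C)/C=N/N=C/c1cn(S(=O)(=O)c2ccccc2)c2cccc([N+](=O)[O-])c12`, gives 1830 nM in this assay. Among the compounds with values here, this places compound 2 at the lower of the two numbers, but the only measured step, a 1.3-fold lower number from compound 1 to compound 2 (0.12 log units; within the scatter), falls within the scatter, so the two values cannot be ranked against each other.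

Compound 3 `COc1ccc(Cl)cc1S(=O)(=O)n1cc(/C=N/N=C/N(C)C)c2c([N+](=O)[O-])cccc21` has not yet been measured. It differs from compound 2 in one place: chloro in place of methoxy on an aromatic carbon. Within the data shown here, the single measured step bears only loosely on this change, since it exchanged the whole phenyl for the 2,5-dimethoxyphenyl and moved the read-out by a 1.3-fold lower number from compound 1 to compound 2 (0.12 log units; within the scatter), within the scatter. Among the measured compounds shown here, nothing measured so far shows that changing a group on this ring shifts the number beyond the scatter. Compound 3 is therefore expected to give about 1200 nM in this assay, with a plausible range from 400 nM to 4000 nM. This estimate amounts to a step of a 1.2-fold lower number from compound 2 to compound 3 (0.07 log units; within the scatter), which is expected to remain within the scatter rather than in any clear direction.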

Compound 3, half-maximal inhibitory concentration: 2440 nM
For compound 3 the middle estimate is 2.0-fold (0.31 log units) below the measured one; low and high end bracket the measured number.
By their numbers in this assay, from the lowest: compounds 2, 1 and 3 (each within the scatter of the next).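

Exchanging methoxy for chloro at this carbon, para to a methoxy group, gives in this assay a 1.7-fold higher number from compound 2 to compound 3 (0.24 log units; within the scatter). At this position, then, the methoxy group, with its 2 heavy atoms and hydrogen-bond acceptor, can give way to the single chlorine atom without a shift that stands clear of the scatter. The comparison with plain phenyl on the sulfonyl sulfur points the same way, with 5-chloro-2-methoxyphenyl giving a 1.3-fold higher number from compound 1 to compound 3 (0.12 log units; within the scatter), so the three groups tried on that sulfur cannot be ranked, and no other measurement is available to shed light on these numbers.

Still open, going by these compounds, is whether any group at this carbon can move the number beyond the scatter, for example an amine, a carboxylic acid or a longer chain such as butoxy. All three compounds also share the same core and side chain, so the compounds shown say nothing about how changes in those parts would register in this assay.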